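Trifluoromethyl on the Phenyl Ring of Compound 1

The compounds below may be only part of what the source reports. "The series", "measured", "known", "first", "only" and "open" are said of these compounds alone.

Going by the values given here, compound 1 `c1ccc(-c2cn3ccnc3c(-c3ccc4ncn(C5CCCCC5)c4c3)n2)cc1` was tested in a functional assay on K562 cells (Homo sapiens) for inhibition, read by sulforhodamine B assay, with a stated time of 48 h, tested at 10 uM (on this read-out lower numbers stand for less inhibition and higher numbers for more inhibition at the one concentration tested (going by the name of the read-out)), and gives 70.6%, the second highest of the three numbers so far. Compound 2 `COc1ccc(-c2cn3ccnc3c(-c3ccc4ncn(C5CCCCC5)c4c3)n2)cc1` gives 92%, and the step of a number 21.4 percentage points higher from compound 1 to compound 2 (beyond the scatter) shows a modest gain. Compound 3 `Fc1ccccc1-c1cn2ccnc2c(-c2ccc3ncn(C4CCCCC4)c3c2)n1` gives 22.8%, and the step of a number 47.8 percentage points lower from compound 1 to compound 3 (beyond the scatter) shows a large loss. The gap a number 69.2 percentage points lower from compound 2 to compound 3 (beyond the scatter) is larger still.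

Compound 4 `FC(F)(F)c1cccc(-c2cn3ccnc3c(-c3ccc4ncn(C5CCCCC5)c4c3)n2)c1` has not been measured in this assay. It differs from compound 1 by trifluoromethyl in place of hydrogen on an aromatic carbon; the group sits on an aromatic carbon of a six-membered aromatic ring of carbon only, meta to a large group. Neither measured step places a group at this position, and neither introduces trifluoromethyl, so they bear on the new compound only loosely: one step moved up modestly, the other moved down largely. A step of uncertain direction is therefore expected, on balance somewhat downward, a number 15.6 percentage points lower from compound 1 to compound 4 (beyond the scatter). Compound 4 is estimated at 55%, within a range from 20% to 85%.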

Compound 4, a percentage reported as inhibition, at one concentration (the size of the read-out at that concentration, not a potency): 21.5%
Estimate against measurement, compound 4: 33.5 percentage points above; the measured number falls inside the stated range.
By their numbers in this assay, from the lowest: compounds 4 and 3 (each within the scatter of the next); then compound 1; then compound 2.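

In this assay, trifluoromethyl on an aromatic carbon meta to a large group brings a number 49.1 percentage points lower from compound 1 to compound 4 (beyond the scatter), so a large loss on the phenyl ring of compound 1 is no longer seen with fluoro alone. With a number 1.3 percentage points lower from compound 3 to compound 4 (within the scatter), 3-(trifluoromethyl)phenyl and 2-fluorophenyl cannot be told apart, while a number 70.5 percentage points lower from compound 2 to compound 4 (beyond the scatter) leaves 4-methoxyphenyl as the one substituted ring shown that goes against this loss. Nothing given here explains the drop.

The compounds shown leave open whether the loss follows the place on the ring or the group itself, as no single group appears at more than one place. They also leave open how an amine or a carboxylic acid on the same aromatic carbon would read in this assay.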